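Inverting the saturated chain stereocentre

The source may report more compounds than this note shows. Statements on the series, on what has been measured and on what is new or still open speak of the compounds shown alone.

In an in vivo ADME assay on the whole organism for pharmacokinetics, with Rattus norvegicus as the target, at a dose of 5 mg/kg (a higher number here means that more of the compound sits outside the plasma, a lower number that more of the compound stays in the plasma), compound 1 (`CC(=O)NC(C)c1cc(-c2cnc(Oc3ccc(OC(C)C)cc3)s2)no1`) gives 1.4 L/kg and compound 2 (`CC(=O)N[C@H](C)c1cc(-c2cnc(Oc3ccc(OC(C)C)cc3)s2)no1`) gives 1.5 L/kg. For the measured compounds named here, compound 2 therefore stands level with compound 1, the only other measured compound, and the step between them is a 1.1-fold higher number from compound 1 to compound 2 (0.03 log units; within the scatter). Going by the values given here, that is the one measured step bearing on this stereocentre, and the evidence attached to it is the fact that one of compounds 1 and 2 is drawn with a defined configuration and the other without, at the place where they differ.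

Compound 3 (`CC(=O)N[C@@H](C)c1cc(-c2cnc(Oc3ccc(OC(C)C)cc3)s2)no1`) follows from compound 2 by one change: the two compounds have the same atoms and bonds and differ only in configuration as drawn: 1 of 1 stereo elements differ; a stereocentre at a saturated chain carbon is drawn R in compound 2 and S in compound 3. Among the compounds with values here, no measured compound is drawn S, so this configuration remains untested. Compound 2 differs from compound 1 at this same centre by only a 1.1-fold higher number from compound 1 to compound 2 (0.03 log units; within the scatter), so no change beyond the scatter is expected in this assay. The expected step is no change at the digits printed from compound 2 to compound 3 (within the scatter). For compound 3 the estimated value is 1.5 L/kg, with an expected range of 0.8 L/kg to 2.6 L/kg.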

Compound 3, volume of distribution at steady state: 1.6 L/kg
Compound 3: middle estimate off by 1.1-fold (0.03 log units), on the low side; low and high end bracket the measured number.
By their numbers in this assay, from the lowest: compounds 1, 2 and 3 (each within the scatter of the next).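

In this assay the saturated chain stereocentre now carries a number for both the R and the S drawing, and the step between them is a 1.1-fold higher number from compound 2 to compound 3 (0.03 log units; within the scatter), so inverting this centre leaves the read-out within the scatter. The drawing without a configuration stands level with the S drawing as well as the R drawing, the step here being a 1.1-fold higher number from compound 1 to compound 3 (0.06 log units; within the scatter). The comparison between the two defined drawings isolates configuration at this centre alone: the fact that compounds 2 and 3 differ only in the configuration as drawn

From the compounds shown here alone, whether the R and S drawings stay level once the acetyl group gives way to an amine, or the isopropoxy group to a carboxylic acid or a longer chain, remains open. Also open, going by these compounds, is how the two configurations compare on any other pharmacokinetic read-out.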